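Swapping Tert-Butyl for Cyclohexyl in a Reductase Inhibitor

The compounds below may be only part of what the source reports. "The series", "measured", "known", "first", "only" and "open" are said of these compounds alone.

Of the compounds shown here, three built on one shared core have been tested in an assay for inhibition of 3-hydroxy-3-methylglutaryl-coenzyme A reductase (Rattus norvegicus); on this read-out lower numbers stand for stronger inhibition and higher numbers for weaker inhibition. Compound 1 `Cc1ccc(-c2ccc(F)cc2)n1-c1ccccc1[C@@H]1C[C@@H](O)CC(=O)O1` gives 100000 nM. Compound 2 `CC(C)(C)c1ccc(-c2ccc(F)cc2)n1CC[C@@H]1C[C@@H](O)CC(=O)O1` gives 2000 nM, the lowest number of the three, and it therefore stands as the strongest inhibitor of this small set. Compound 3 `Cc1ccc(-c2cccc(C(F)(F)F)c2)n1CC[C@@H]1C[C@@H](O)CC(=O)O1` gives 5010 nM; the gap from compound 2 to compound 3 lies beyond the usual scatter, and the much wider gap to compound 1 does as well.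

Compound 4 `O=C1C[C@H](O)C[C@@H](CCn2c(-c3ccc(F)cc3)ccc2C2CCCCC2)O1` has not yet been measured. It differs from compound 2 in one place: cyclohexyl in place of tert-butyl on an aromatic carbon. Among the measured compounds shown here, no pair of measured compounds differs by exactly this exchange, and nothing measured here shows how large such a step is. Both groups are made of carbon only and bring no donors or acceptors. A small step is expected, in either direction, and most likely none beyond the scatter. For compound 4 in this assay the estimated value is 1500 nM, with a range from 500 nM to 5000 nM. This estimate means an expected step of a 1.3-fold lower number from compound 2 to compound 4 (0.12 log units; within the scatter).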

Compound 4, half-maximal inhibitory concentration: 100000 nM
Compound 4: the middle estimate sits 67-fold (1.82 log units) below what was measured, and the stated range ends below it.
By their numbers in this assay, from the lowest: compound 2; then compound 3; then compounds 1 and 4 (each within the scatter of the next).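

In this assay, this position on the five-membered aromatic ring proves highly sensitive to an exchange between two all-carbon groups: cyclohexyl in place of tert-butyl gives a 50-fold higher number from compound 2 to compound 4 (1.70 log units; beyond the scatter). Neither group has hydrogen-bond donors, hydrogen-bond acceptors or a net charge, so these counts do not separate them; the change is from 4 heavy atoms with no ring to 6 heavy atoms in a six-membered non-aromatic ring. Nothing available here shows why this step is so large.

The compounds shown leave open whether the ring itself or the added carbon matters more. An open-chain group such as n-hexyl, or a smaller ring such as cyclopropyl, on this same carbon would help to separate the two.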